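A few compounds are considered here, and "the series" means these few. Any claim that something is new, unique, unknown or untested is made for them only; others in the source may bear on it.

Compounds measured in a physicochemical assay for lipophilicity, in phosphate buffer, measured as octanol-water partition, with a stated time of 24 h; a higher number here means a more lipophilic compound, a lower number a more polar compound:

compound 1, `S=C(N/N=C/c1ccc(Oc2ccc(Br)cc2)cc1)Nc1ccccc1`, 5.62
compound 2, `S=C(N/N=C/c1ccc(Oc2ccc(Cl)cc2)cc1)Nc1ccccc1`, 5.52
compound 3, `Cc1ccc(Oc2ccc(/C=N/NC(=S)Nc3ccc(Cl)cc3)cc2)cc1`, 5.97

Compound 2 and compound 1 share one core and differ by bromo in place of chloro on an aromatic carbon. The step of a number 0.10 log units higher from compound 2 to compound 1 (within the scatter). Compound 3 stands on a different core; how its core differs from that of compound 2 is not broken down here. Compound 3 gives the highest of the three numbers, with compound 1 the nearest and compound 2 the furthest, both beyond the scatter.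

Compound 4, `Cc1ccc(Oc2ccc(/C=N/NC(=S)Nc3ccc(Br)cc3)cc2)cc1`, has not yet been measured in this assay. It differs from compound 3 by bromo in place of chloro on an aromatic carbon. This is the same change as that from compound 2 to compound 1, read on another core: cut one bond further out it reads (4-chlorophenyl)amino to (4-bromophenyl)amino in compound 3 and compound 4, against 4-chlorophenoxy to 4-bromophenoxy in compound 2 and compound 1. Because a number 0.10 log units higher from compound 2 to compound 1 (within the scatter), the same step is expected here. For compound 4 the value is expected to be 6.07, between 5.8 and 6.35. Within the data shown here, that estimate means a step of a number 0.10 log units higher from compound 3 to compound 4 (within the scatter), resting on the single measured pair.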

Compound 4, partition coefficient: 6.17
Estimate against measurement, compound 4: 0.10 log units below; the range from low to high includes it.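

In this assay, bromo in place of chloro on an aromatic carbon gives a number 0.20 log units higher from compound 3 to compound 4 (within the scatter) on one core, against a number 0.10 log units higher from compound 2 to compound 1 (within the scatter) on the other, so on these two cores the change carries across with neither step beyond the scatter. This is agreement between two small steps, each resting on a single pair of compounds, and it does not show that the exchange truly moves the number in either pair, nor that it would behave alike on a third core. Nothing measured here bears on what lies behind either step.

The compounds shown leave open whether fluoro or iodo at the same place would give a step of similar size, and whether a group of a different kind, such as an amine or a carboxylic acid, would carry from one core to the other in the same way. Cores beyond these two also remain open.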